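Hydroquinone to quinone on a pyrazole sulfonamide series

A few compounds are considered here, and "the series" means these few. Any claim that something is new, unique, unknown or untested is made for them only; others in the source may bear on it.

Compound 1 `COc1ccc(OC)c(-c2cc(-c3ccccc3)nn2-c2ccc(S(=O)(=O)NC(C)=O)cc2)c1`: 15400 nM
Compound 2 `CC(=O)NS(=O)(=O)c1ccc(-n2nc(-c3ccccc3)cc2-c2cc(O)ccc2O)cc1`: 84800 nM
Compound 3 `CC(=O)NS(=O)(=O)c1ccc(-n2nc(-c3ccc(Cl)cc3)cc2-c2cc(O)ccc2O)cc1`: 36200 nM

In a functional assay on cells (Melanoma cell, Homo sapiens) for cytotoxicity, read by sulforhodamine B assay, with a stated time of 48 h (on this read-out lower numbers stand for stronger inhibition of growth and higher numbers for weaker inhibition of growth), compound 2 has the highest number of the three, with compound 3 nearest and compound 1 furthest. Compound 4 `CC(=O)NS(=O)(=O)c1ccc(-n2nc(-c3ccccc3)cc2C2=CC(=O)C=CC2=O)cc1` differs from compound 2 in that (a group of 8 heavy atoms (6 carbon, 2 oxygen; one six-membered non-aromatic ring of carbon only) in place of a group of 8 heavy atoms (6 carbon, 2 oxygen; one six-membered aromatic ring of carbon only), on an aromatic carbon). Neither measured step touches this position: a 5.5-fold higher number from compound 1 to compound 2 (0.74 log units; beyond the scatter) and a 2.3-fold lower number from compound 2 to compound 3 (0.37 log units; beyond the scatter) concern other places and give no guide here. Going by the values given here, with no step bearing on the change, the expectation for compound 4 is an uncertain one, set wide around the value of compound 2. Compound 4 is therefore expected to give 30000 nM, within 7000 nM to 130000 nM. This estimate means a 2.8-fold lower number from compound 2 to compound 4 (0.45 log units; beyond the scatter), a step that is expected but not supported by any measured pair.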

Compound 4, concentration for 50% growth inhibition: 92000 nM
The estimate for compound 4 lay 3.1-fold (0.49 log units) below the measured number; low and high end bracket the measured number.
By their numbers in this assay, from the lowest: compound 1; then compound 3; then compounds 2 and 4 (each within the scatter of the next).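

In this assay, the non-aromatic six-membered ring in place of 2,5-dihydroxyphenyl gives a 1.1-fold higher number from compound 2 to compound 4 (0.04 log units; within the scatter), so at this position the loss of the aromatic ring and the hydrogen-bond donors leaves the number within the scatter. Against 2,5-dimethoxyphenyl, the same ring gives a 6.0-fold higher number from compound 1 to compound 4 (0.78 log units; beyond the scatter), so of the three groups tested here only 2,5-dimethoxyphenyl stands apart. No measurement shown here accounts for this result. The compounds shown leave open how an amine or a carboxylic acid would behave at this position, and whether chloro on the phenyl group would give a similar step alongside the non-aromatic ring.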